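Branch lengthening on the amine of a pyrazolopyrimidine-type core

The source may report more compounds than this note shows. Statements on the series, on what has been measured and on what is new or still open speak of the compounds shown alone.

Compound 1, `CCCC(CCOC)Nc1nc(C)nc2c1cnn2-c1ccc(OC)cc1C`, gives 132 nM in a functional assay on CHO cells for antagonist activity at corticotropin-releasing factor receptor 1 (Homo sapiens), read by cAMP accumulation; a lower number here means a stronger inhibitor, a higher number a weaker inhibitor.
Compound 2, `CCC(CC)Nc1nc(C)nc2c1cnn2-c1ccc(OC)cc1C`, gives 85 nM in this assay.

For the measured compounds named here, compound 2 holds the lower of the two numbers measured so far, with compound 1 nearest to it; the one step between them, a 1.6-fold lower number from compound 1 to compound 2 (0.19 log units; within the scatter), lies within the scatter. Compound 3, `CCCC(CCC)Nc1nc(C)nc2c1cnn2-c1ccc(OC)cc1C`, has not yet been measured in this assay. It differs from compound 2 by 1-propylbutyl in place of pentan-3-yl on a nitrogen on an aromatic ring, that is, the chain on the amine grows by one carbon on each side.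

Going by the values given here, only the step from compound 1 to compound 2 bears on this change, and it was small, so compound 3 is expected to sit close to compound 2, with any shift likely within the scatter. Compound 3 is therefore expected to give 70 nM in this assay, between 30 nM and 180 nM, which corresponds to an expected step of a 1.2-fold lower number from compound 2 to compound 3 (0.08 log units; within the scatter).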

Compound 3, inhibition constant: 32 nM
Compound 3: the middle estimate sits 2.2-fold (0.34 log units) above what was measured; low and high end bracket the measured number.
By their numbers in this assay, from the lowest: compound 3; then compounds 2 and 1 (each within the scatter of the next).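

In this assay, for the compounds shown here, the group on the nitrogen can shift the number beyond the scatter: 1-propylbutyl in place of pentan-3-yl gives a 2.7-fold lower number from compound 2 to compound 3 (0.42 log units; beyond the scatter), whereas the only earlier step stayed within it. Methyl in place of methoxy on the saturated chain gives a 4.1-fold lower number from compound 1 to compound 3 (0.62 log units; beyond the scatter), so this change too is now seen to register beyond the scatter, which compound 1 and compound 2 alone could not show. Nothing available explains either step.

The compounds shown leave open whether a longer chain, such as 1-butylpentyl, would carry the number lower still or reverse the step. They also leave open how a ring on the nitrogen, such as cyclopentyl, or a hydroxyl in place of methoxy on the chain, would compare with 1-propylbutyl.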